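Cytotoxicity of a benzylimidazole series: from compound 1 to compound 4

A few compounds are considered here, and "the series" means these few. Any claim that something is new, unique, unknown or untested is made for them only; others in the source may bear on it.

Compound 1: `COC(=O)c1ccc(NCc2cncn2Cc2ccccc2-c2ccccc2)cc1-c1ccccc1` — in a toxicity assay on NIH3T3 cells (Mus musculus) for cytotoxicity, read by resazurin assay (on this read-out lower numbers stand for an effect already at smaller amounts and higher numbers for an effect only at larger amounts of compound), compound 1 gives "not determined" (no result reported)
Compound 2: `CCOC(=O)c1ccc(NCc2cncn2Cc2ccc(-c3ccccc3)cc2)cc1-c1ccccc1` — > 10000 nM
Compound 3: `c1ccc(-c2ccc(Cn3cncc3CNc3ccc(N4CCCC4)c(-c4ccccc4)c3)cc2)cc1` — > 1000 nM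

The values for compound 2 and compound 3 are limits of this assay, not numbers. For compound 2 the value sits at the limit of > 10000 nM in this assay, at which 1 of the 3 values shown sits. For compound 3 the value sits at the limit of > 1000 nM in this assay, at which 1 of the 3 values shown sits. On these data alone, compound 1 has no result at all in this assay, so its standing among the three is unknown. Within the data shown here, the only measured step, a step that the two limits leave unreadable from compound 2 to compound 3, cannot be read because both ends are limits.

Compound 4 is `COC(=O)c1ccc(NCc2cncn2Cc2cccc(C#N)c2)cc1-c1ccccc1`. It differs from compound 1 by 3-cyanophenyl in place of 2-phenylphenyl on a saturated chain carbon bound to an aromatic nitrogen. Among the measured compounds shown here, no measured step bears on this change, and no number exists for compound 1 to start from. Since the two values shown are limits, the estimate for compound 4 is 15000 nM, within 3000 nM to 60000 nM.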

Compound 4, half-maximal effective concentration: > 10000 nM
Compound 4: no number, only a limit (the forecaster's own chance of this, stated with the estimate: 70%); the middle value lies beyond the limit too.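

In this assay compound 4 gives > 10000 nM as a limit and not a number. Among these compounds, no step from compound 1 to compound 4 can be read. The compounds shown leave open at what concentration any of them takes effect.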